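Swapping an Amine Substituent on the Shared Core

This account rests on a few compounds, and the source may have more. Where it says the series, first, only, none or still open, it means among the compounds named here.

Compound 1, `CCCc1nn(C)c2c(NC(C)C)nc(/C=C/c3cccnc3)nc12`, is the starting point. In a functional assay on L02 cells (Homo sapiens) for inhibition, read by Griess assay, with stated times of 1 h and 24 h (on this read-out higher numbers stand for weaker inhibition and lower numbers for stronger inhibition), compound 1 gives 574000 nM. Two changes to it have been measured, each at a different place.

Compound 2, `CCCc1nn(C)c2c(NCc3ccc(F)cc3)nc(/C=C/c3cccnc3)nc12`, carries the change (4-fluorobenzyl in place of isopropyl on a nitrogen on an aromatic ring). In this assay compound 2 gives 940000 nM, which is a 1.6-fold higher number from compound 1 to compound 2 (0.21 log units; within the scatter).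

Compound 3, `CCCc1nn(C)c2c(NC(C)C)nc(/C=C/c3ccc[n+]([O-])c3)nc12`, carries the change (a group of 7 heavy atoms (5 carbon, 1 nitrogen, 1 oxygen; one six-membered aromatic ring with 1 hetero atom) in place of a group of 6 heavy atoms (5 carbon, 1 nitrogen; one six-membered aromatic ring with 1 hetero atom), on a double-bonded chain carbon bound to a double-bonded chain carbon). In this assay compound 3 gives 324000 nM, which is a 1.8-fold lower number from compound 1 to compound 3 (0.25 log units; within the scatter). Compound 3 and compound 2 are separated by a gap that lies beyond the scatter, while compound 3 and compound 1 lie within the scatter of each other.

Compound 4, `CCCc1nn(C)c2c(NCc3ccc(F)cc3)nc(/C=C/c3ccc[n+]([O-])c3)nc12`, has not been measured. It differs from compound 3 by 4-fluorobenzyl in place of isopropyl on a nitrogen on an aromatic ring. This is the same change already seen between compound 1 and compound 2, and it occurs in two pairs among these compounds; the place is described in the same words in both pairs. The two cores differ, however, by a group of 7 heavy atoms (5 carbon, 1 nitrogen, 1 oxygen; one six-membered aromatic ring with 1 hetero atom) in place of a group of 6 heavy atoms (5 carbon, 1 nitrogen; one six-membered aromatic ring with 1 hetero atom), on a double-bonded chain carbon bound to a double-bonded chain carbon, so the surroundings of the change are not identical.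

Because the step of a 1.6-fold higher number from compound 1 to compound 2 (0.21 log units; within the scatter) lay within the scatter, the corresponding step from compound 3 is expected to be similarly small. For compound 4 the expected step is a 1.6-fold higher number from compound 3 to compound 4 (0.21 log units; within the scatter). In this assay, within the data shown here, compound 4 is estimated at 520000 nM, with a range from 250000 nM to 1100000 nM reflecting that only one earlier example of this change exists.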

Compound 4, half-maximal inhibitory concentration: < 40000 nM
Compound 4: a limit, no number; the forecaster's own chance of this, stated with the estimate: 5%; middle value at least 13-fold (1.11 log units) from the limit.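

In this assay compound 4 gives < 40000 nM, which is a limit of the assay and not a number. Even with only a limit, the swap of isopropyl for 4-fluorobenzyl does not carry over unchanged from one core to the other, for the step is now an at least 8.1-fold lower number from compound 3 to compound 4 (0.90 log units; beyond the scatter), and it differs from the earlier step on the core of compound 1: the same change on two cores in this assay, a 1.6-fold higher number (0.21 log units; within the scatter) from compound 1 to compound 2 and an at least 8.1-fold lower number (0.90 log units; beyond the scatter) from compound 3 to compound 4, at least 13-fold (1.12 log units) apart, beyond the scatter of two such steps The other change, the group with the added oxygen atom, tells the same story with an at least 23-fold lower number from compound 2 to compound 4 (1.37 log units; beyond the scatter), so the two changes do not simply add up in these four compounds, but the limit hides the full size of both steps, and one pair of cores gives no rule for any other core: the same change on two cores in this assay, a 1.8-fold lower number (0.25 log units; within the scatter) from compound 1 to compound 3 and an at least 23-fold lower number (1.37 log units; beyond the scatter) from compound 2 to compound 4, at least 13-fold (1.12 log units) apart, beyond the scatter of two such steps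

The compounds shown leave open whether this stronger inhibition depends on the fluorine, which a plain benzyl group on the same nitrogen could test, and whether a longer chain such as butyl in place of isopropyl would behave in the same way. They also leave open how far the real value of compound 4 lies past its limit, and so how large the gap between the two cores really is.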